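This account rests on a few compounds, and the source may have more. Where it says the series, first, only, none or still open, it means among the compounds named here.

For the measured compounds named here, in a functional assay on Hs 683 cells (Homo sapiens) for inhibition, read by colorimetric assay and MTT assay, with a stated time of 72 h (on this read-out higher numbers stand for weaker inhibition and lower numbers for stronger inhibition), three compounds sharing one core have numbers so far. Compound 1 (`C/C1=C\CC[C@@]2(C)O[C@@H]2[C@H]2OC(=O)[C@@H](CN3CCN(C)CC3)[C@@H]2C[C@H]1O`) gives 33000 nM and compound 2 (`C/C1=C\CC[C@@]2(C)O[C@@H]2[C@H]2OC(=O)[C@@H](CN3CCCC3)[C@@H]2C[C@@H]1O`) gives 10000 nM. Compound 3 (`C/C1=C\CC[C@@]2(C)O[C@@H]2[C@H]2OC(=O)[C@@H](CN3CCCCC3)[C@@H]2C[C@@H]1O`) gives 7000 nM, which puts it at the low end of the numbers together with compound 2 and clearly apart from compound 1.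

Compound 4 (`C/C1=C\CC[C@@]2(C)O[C@@H]2[C@H]2OC(=O)[C@@H](CN3CCN(C)CC3)[C@@H]2C[C@@H]1O`) has not been measured. The change from compound 3 is 4-methylpiperazin-1-yl in place of piperidin-1-yl on a saturated chain carbon bound to a saturated ring carbon, so 4-methylpiperazin-1-yl stands in place of piperidin-1-yl on a saturated chain carbon bound to a saturated ring carbon.

Going by the values given here, one measured step touches this place, a 1.4-fold lower number from compound 2 to compound 3 (0.15 log units; within the scatter), but it does not involve 4-methylpiperazin-1-yl and is too small to point in any direction. The better guide is compound 1, which also carries 4-methylpiperazin-1-yl and gives 33000 nM, though one compound is thin evidence.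

In this assay a moderate step towards weaker inhibition is therefore expected, a 2.1-fold higher number from compound 3 to compound 4 (0.33 log units; beyond the scatter). For compound 4 the estimated value is 15000 nM, with an expected range from 6000 nM to 40000 nM.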

Compound 4, half-maximal inhibitory concentration: 22000 nM
Beside the measured number, compound 4's estimate is 1.5-fold (0.17 log units) below it; low and high end bracket the measured number.
By their numbers in this assay, from the lowest: compounds 3 and 2 (each within the scatter of the next); then compounds 4 and 1 (each within the scatter of the next).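

For the compounds shown here, with compound 4, 4-methylpiperazin-1-yl can for the first time be compared directly with the other two amines at this place, with the same configuration as drawn. In this assay it gives weaker inhibition than either, by modest steps (a 3.1-fold higher number from compound 3 to compound 4 (0.50 log units; beyond the scatter)) and (a 2.2-fold higher number from compound 2 to compound 4 (0.34 log units; beyond the scatter)). Changing the configuration at the one stereocentre gives no difference beyond the scatter (a 1.5-fold lower number from compound 1 to compound 4 (0.18 log units; within the scatter)), and this comparison isolates that single feature: the fact that compounds 1 and 4 differ only in the configuration as drawn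

On these data alone, it remains open whether an open-chain amine such as diethylamino, or a ring amine carrying oxygen such as morpholin-4-yl, would give stronger or weaker inhibition at this place. As far as these compounds go, the effect of the opposite configuration on the pyrrolidin-1-yl and piperidin-1-yl compounds also remains open, as only 4-methylpiperazin-1-yl appears here in both forms.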